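Removing the cyclohexyl group from compound 3

The source may hold more compounds than are shown below. What is called first, only, known or untested is meant among the compounds shown, and "the series" means these compounds.

Compound 3 `c1nc2ccc(C3CCCCC3)cc2cc1-c1nn[nH]n1` is measured in a functional assay on the whole organism (strain Sprague-Dawley) for inhibition, with Rattus norvegicus as the target (on this read-out higher numbers stand for an effect only at larger amounts of compound and lower numbers for an effect already at smaller amounts), where compound 3 gives 5 mg/kg. Compound 2 `COc1ccc2cc(-c3nn[nH]n3)cnc2c1` gives 5 mg/kg in this assay, which is level with compound 3 at the digits printed and within the scatter. Compound 1 `Fc1ccc2ncc(-c3nn[nH]n3)cc2c1` gives only a limit of the assay, < 25 mg/kg, in this assay. The step that the limit leaves unreadable from compound 1 to compound 3 is therefore not readable in size due to the limit of < 25 mg/kg in this assay, at which 1 of the 3 values shown sits.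

Compound 4 `c1ccc2ncc(-c3nn[nH]n3)cc2c1` has not yet been measured. It differs from compound 3 by hydrogen in place of cyclohexyl on an aromatic carbon. Within the data shown here, no measured step follows this change directly: the only step that touches the cyclohexyl group, from compound 1 to compound 3, cannot be read, and the pair of compound 2 and compound 3 shows two values within the scatter of each other. The author therefore expects a step of a 2.0-fold higher number from compound 3 to compound 4 (0.30 log units; within the scatter) for compound 4, towards an effect only at somewhat larger amounts, but of uncertain size. In this assay compound 4 is estimated at 10 mg/kg, with a range from 3 mg/kg to 30 mg/kg.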

Compound 4, minimum effective dose: 10 mg/kg
Estimate against measurement, compound 4: no gap at the digits printed; the measured number falls inside the stated range.
By their numbers in this assay, from the lowest: compounds 2, 3 and 4 (each within the scatter of the next).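

Hydrogen in place of cyclohexyl gives a 2.0-fold higher number from compound 3 to compound 4 (0.30 log units; within the scatter) in this assay, so a whole six-membered carbon ring on this aromatic carbon can go without a step beyond the scatter, which the earlier compounds could not show. Hydrogen in place of methoxy on an aromatic carbon gives a 2.0-fold higher number from compound 2 to compound 4 (0.30 log units; within the scatter), so compound 4 also provides the unsubstituted reference that was missing, and neither group stands apart from it. Compound 1 carries a limit, and its steps to compound 3 and to compound 4 cannot be read for that reason: the limit of < 25 mg/kg in this assay, at which 1 of the 4 values shown sits.

The compounds shown therefore do not tell whether any group on this aromatic carbon moves the dose beyond the scatter. On these data alone, whether an amine, a carboxylic acid or a longer alkyl chain there would do so remains open.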